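The source may report more compounds than this note shows. Statements on the series, on what has been measured and on what is new or still open speak of the compounds shown alone.

Within the data shown here, compound 2 `N#Cc1ccccc1OC1CCN(c2ccc(-n3ccnc3)nn2)CC1` gives 236 nM in an assay on microsomes from liver for inhibition of acyl-CoA desaturase 1 (Rattus norvegicus) (a lower number here means a stronger inhibitor, a higher number a weaker inhibitor), the higher of the two numbers measured so far, while compound 1 `Cc1ccccc1OC1CCN(c2ccc(-n3ccnc3)nn2)CC1` gives 39 nM. Compound 3 `Brc1cccc(OC2CCN(c3ccc(-n4ccnc4)nn3)CC2)c1` differs from compound 2 by 3-bromophenyl in place of 2-cyanophenyl on an oxygen on a saturated carbon. Among the measured compounds shown here, the only measured step bearing on this change is a 6.1-fold higher number from compound 1 to compound 2 (0.78 log units; beyond the scatter), which also turned on the cyano group; since compound 3 removes that group again, a lower number is expected, though the bromine has no measured counterpart and the size is uncertain. Compound 3 is therefore expected to give 60 nM (range 20 nM to 200 nM) in this assay, a step of a 3.9-fold lower number from compound 2 to compound 3 (0.59 log units; beyond the scatter).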

Compound 3, half-maximal inhibitory concentration: 23 nM
Beside the measured number, compound 3's estimate is 2.6-fold (0.42 log units) above it; the range from low to high includes it.
By their numbers in this assay, from the lowest: compounds 3 and 1 (each within the scatter of the next); then compound 2.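

In this assay, 3-bromophenyl in place of 2-cyanophenyl on an oxygen on a saturated carbon gives a 10-fold lower number from compound 2 to compound 3 (1.01 log units; beyond the scatter) and shows that this place does not itself limit the series. The change of 2-methylphenyl to 3-bromophenyl gives a 1.7-fold lower number from compound 1 to compound 3 (0.23 log units; within the scatter) and so does not separate these two groups. No evidence given here accounts for these steps. The group and its place on the phenyl ring change together in these steps, so their contributions remain unresolved. As far as these compounds go, how an amine or a carboxylic acid on that ring would behave also remains open.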